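Hydroxy(phenyl)methyl Ester on the Shared Core

The source may report more compounds than this note shows. Statements on the series, on what has been measured and on what is new or still open speak of the compounds shown alone.

Three esters of one core have been measured in a functional assay on NFS-60 cells (Mus musculus) for inhibition, read by MTT assay, with a stated time of 72 h; on this read-out higher numbers stand for weaker inhibition and lower numbers for stronger inhibition. Compound 1 `O=C(OC1(C(=O)Nc2ccc([N+](=O)[O-])cc2)CCCCC1)c1ccc(Cl)cc1` gives 10.3 nM, compound 2 `O=C(OC1(C(=O)Nc2ccc([N+](=O)[O-])cc2)CCCCC1)c1ccc([N+](=O)[O-])cc1` gives 7.7 nM, and compound 3 `CCC(=O)OC1(C(=O)Nc2ccc([N+](=O)[O-])cc2)CCCCC1` gives 6.4 nM. Compound 3 holds the lowest of the three numbers, though the steps of a 1.6-fold lower number from compound 1 to compound 3 (0.21 log units; within the scatter) and a 1.2-fold lower number from compound 2 to compound 3 (0.08 log units; within the scatter) both lie within the scatter. Compound 4 `O=C(OC1(C(=O)Nc2ccc([N+](=O)[O-])cc2)CCCCC1)C(O)c1ccccc1` differs from compound 3 by hydroxy(phenyl)methyl in place of ethyl on a carbonyl carbon. For the measured compounds named here, the two measured steps at that carbonyl carbon show that exchanging the ester group left this assay unchanged beyond the scatter; the entering group brings a hydrogen-bond donor and acceptor for which no measured step exists. The step of a 1.2-fold higher number from compound 3 to compound 4 (0.07 log units; within the scatter) is therefore expected to stay within the scatter. Compound 4 is estimated at 7.5 nM, with a range from 3 nM to 20 nM.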

Compound 4, half-maximal inhibitory concentration: 7.8 nM
Estimate against measurement, compound 4: 1.0-fold (0.02 log units) below, within the range that was stated.
By their numbers in this assay, from the lowest: compounds 3, 2, 4 and 1 (each within the scatter of the next).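

In this assay, for the compounds shown here, hydroxy(phenyl)methyl on the carbonyl carbon is the only group of the four that carries a hydrogen-bond donor, and it stays within the scatter of all three earlier esters: a 1.2-fold higher number from compound 3 to compound 4 (0.09 log units; within the scatter), a 1.0-fold higher number from compound 2 to compound 4 (0.01 log units; within the scatter) and a 1.3-fold lower number from compound 1 to compound 4 (0.12 log units; within the scatter). The flat picture at this position thus extends to an entering group with a hydrogen-bond donor and a six-membered aromatic ring held on a carbon away from the carbonyl. Nothing shown here gives a reason for this flatness. Going by these compounds, whether any change at this carbonyl carbon can move the number beyond the scatter remains open; an amine or a carboxylic acid in the entering group would test that.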